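Chloro to Methoxy on a Long-Lived Microsomal Stability Compound

This account rests on a few compounds, and the source may have more. Where it says the series, first, only, none or still open, it means among the compounds named here.

Measured in an ADME assay on microsomes from liver (Homo sapiens) for metabolic stability; on this read-out lower numbers stand for a shorter-lived compound and higher numbers for a longer-lived compound:
- compound 1, `COc1ccc(-c2cnc(NC(=O)c3ccc(F)cc3)n2C)cc1`: 0.983 h
- compound 2, `Cn1c(-c2ccc(Cl)cc2)cnc1NC(=O)c1ncc[nH]1`: > 4.25 h

In this assay compound 1 gives 0.983 h, a number. Compound 2 stands apart: its result, > 4.25 h, is a limit of the assay, not a number, as shown by the limit of > 4.25 h in this assay, at which 1 of the 2 values shown sits. For the measured compounds named here, the two compounds differ in more than one place, so their values are only two separate readings.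

The next compound, compound 3, `COc1ccc(-c2cnc(NC(=O)c3ncc[nH]3)n2C)cc1`, is made from compound 2 by one change: methoxy in place of chloro on an aromatic carbon.

Going by the values given here, no measured step between two compounds differing in one place exists here, so the size of this step is a guess. Compound 3 is expected to stay long-lived, with a step of an at least 1.4-fold lower number from compound 2 to compound 3 (0.15 log units; that floor lies within the scatter) counted as a modest move, possibly none beyond the scatter. The estimate for compound 3 in this assay is 3 h, in the range 1 h to 6 h.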

Compound 3, half-life in the Homo sapiens assay: > 4.25 h
Compound 3: no number, only a limit; the forecaster's own chance of this, stated with the estimate: 40%; middle value at least 1.4-fold (0.15 log units) from the limit.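

In the Homo sapiens assay, compound 2 and compound 3 both sit at the assay's limit, so the step between them cannot be read, and methoxy in place of chloro shows no measurable loss of half-life: the limit of > 4.25 h in the Homo sapiens assay, at which 2 of the 3 values shown sit.

With 1H-imidazol-2-yl in place of 4-fluorophenyl on the carbonyl carbon, the Homo sapiens assay gives an at least 4.3-fold higher number from compound 1 to compound 3 (0.63 log units; beyond the scatter).

The change at the chloro position can be read in a physicochemical assay for solubility, read by nephelometry, measured as kinetic solubility, at pH 6.5 (a lower number here means a less soluble compound, a higher number a more soluble compound), where compound 2 gives 25 ug/mL and compound 3 gives 6.3 ug/mL, a 4.0-fold lower number from compound 2 to compound 3 (0.60 log units; beyond the scatter).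

From the compounds shown here alone, how far the true half-lives of compound 2 and compound 3 lie past the limit stays open, so any effect of this change on half-life remains hidden. Also open, going by these compounds, is whether an amine on the same aromatic carbon would hold the half-life at the limit while giving solubility closer to that of compound 2.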